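The compounds below may be only part of what the source reports. "The series", "measured", "known", "first", "only" and "open" are said of these compounds alone.

Measured in a functional assay on the whole organism (Ear, strain ICR) for inhibition, with Mus musculus as the target, with stated times of 30 min and 2 h, at a dose of 10 umol/kg by the oral route; a lower number here means less inhibition, a higher number more inhibition at the dose given (going by the name of the read-out):
Compound 1 `CC(=O)OC[C@H]1O[C@H](OC(C)=O)[C@H](NC(=O)[C@@H](NCCC2OCC(C)(C)CO2)C(C)C)[C@@H](OC(C)=O)[C@@H]1OC(C)=O` gives 70.6%.
Compound 2 `CC(=O)OC[C@H]1O[C@H](OC(C)=O)[C@H](NC(=O)[C@H](C)NCCC2OCC(C)(C)CO2)[C@@H](OC(C)=O)[C@@H]1OC(C)=O` gives 84.2%.
Compound 3 `CC(C)[C@H](NCCC1OCC(C)(C)CO1)C(=O)N[C@H]1C(O)O[C@H](CO)[C@@H](O)[C@@H]1O` gives 85.1%.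

Compound 1 and compound 2 share the core of compound 1 and differ in one place: methyl in place of isopropyl on a saturated chain carbon bound to an amine nitrogen and a carbonyl carbon. That change produced a number 13.6 percentage points higher from compound 1 to compound 2 (beyond the scatter). Compound 3 has a different core; the difference between the two cores is not broken down here. In this assay compound 3 and compound 2 lie within the scatter of each other, while compound 3 stands beyond the scatter above compound 1.

Compound 4 `C[C@H](NCCC1OCC(C)(C)CO1)C(=O)N[C@H]1C(O)O[C@H](CO)[C@@H](O)[C@@H]1O` has not yet been measured. It relates to compound 3 exactly as compound 2 relates to compound 1, through the same change: methyl in place of isopropyl on a saturated chain carbon bound to an amine nitrogen and a carbonyl carbon. Because the earlier step was a number 13.6 percentage points higher from compound 1 to compound 2 (beyond the scatter), a rise is expected here too, though a smaller one, since the read-out is a percentage and compound 3 already starts high at 85.1%. The expected step is a number 3.9 percentage points higher from compound 3 to compound 4 (within the scatter). Compound 4 is accordingly estimated at 89%, with a likely range from 74% to 98%.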

Compound 4, a percentage reported as inhibition, in the whole organism at one dose (the size of the read-out at that dose, not a potency): 86.8%
Compound 4: middle estimate off by 2.2 percentage points, on the high side; low and high end bracket the measured number.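

In this assay, methyl in place of isopropyl on a saturated chain carbon bound to an amine nitrogen and a carbonyl carbon gave a number 1.7 percentage points higher from compound 3 to compound 4 (within the scatter), so on this core the two compounds cannot be told apart. Set beside the step on the core of compound 1, this result gives no sign that the effect of the change depends on the core: the same change on two cores in this assay, a number 13.6 percentage points higher (beyond the scatter) from compound 1 to compound 2 and a number 1.7 percentage points higher (within the scatter) from compound 3 to compound 4, 11.9 percentage points apart, within the scatter of two such steps This does not show that the step has the same size on both cores, as each core supplies only one pair, both values on this core lie high on a percentage scale, and the read-out comes from a single dose and is not a potency.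

The compounds shown leave open how other groups on this chain carbon, such as an ethyl, a benzyl or a hydroxymethyl group, would compare with methyl and isopropyl on either core. They also leave open whether the change would read the same way at other doses.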